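The compounds below may be only part of what the source reports. "The series", "measured", "known", "first", "only" and "open" are said of these compounds alone.

In a physicochemical assay for lipophilicity (a lower number here means a more polar compound, a higher number a more lipophilic compound), compound 1 (`Brc1cccc(Br)c1N(CC1CC1)C1=NCCN1`) gives -1.12 and compound 2 (`Brc1ccc(Br)c(N(CC2CC2)C2=NCCN2)c1`) gives -0.52. Compound 3 (`CCCCCN(C1=NCCN1)c1c(Br)cccc1Br`) gives 0.32, the highest of the three numbers. Compound 4 (`C=CCN(C1=NCCN1)c1c(Br)cccc1Br`) differs from compound 3 in one place: vinyl in place of butyl on a saturated chain carbon bound to a nitrogen on an aromatic ring. This puts vinyl in place of butyl on a saturated chain carbon bound to a nitrogen on an aromatic ring, which also reads as pentyl to allyl. Going by the values given here, the only measured step at this place also concerns butyl: a number 1.44 log units higher from compound 1 to compound 3 (beyond the scatter). With butyl now leaving, a large step toward lower numbers, of similar size, is expected in this assay. The expected step is a number 1.32 log units lower from compound 3 to compound 4 (beyond the scatter). For compound 4 the estimated value is -1, with an expected range from -1.5 to -0.5.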

Compound 4, distribution coefficient: -0.75
For compound 4 the middle estimate is 0.25 log units below the measured one; the range from low to high includes it.
By their numbers in this assay, from the lowest: compound 1; then compounds 4 and 2 (each within the scatter of the next); then compound 3.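

In this assay, vinyl in place of butyl on a saturated chain carbon bound to a nitrogen on an aromatic ring gives a number 1.07 log units lower from compound 3 to compound 4 (beyond the scatter) and thus a second large step at this place. Vinyl in place of cyclopropyl gives a number 0.37 log units higher from compound 1 to compound 4 (beyond the scatter) and is a smaller step, so among these three groups butyl stands well apart from the other two. Nothing available here explains these steps.

This change shortens the chain and brings in a double bond together, and the compounds shown do not separate the two. On these data alone, how ethyl, a longer chain or an amine would behave at this place remains open.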